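Trading the methoxyphenyl arm of compound 1 for a fluoromethylphenyl

The source may report more compounds than this note shows. Statements on the series, on what has been measured and on what is new or still open speak of the compounds shown alone.

Compound 1 `COc1ccc(F)cc1Nc1cc(NC(=O)Nc2c(Cl)cccc2Cl)ncn1` is measured in a functional assay on PC-9 cells (Homo sapiens) for inhibition, read by MTT assay, with a stated time of 48 h, tested at 10 uM (on this read-out higher numbers stand for more inhibition at the one concentration tested (going by the name of the read-out) and lower numbers for less inhibition), and gives 85.5%. Among the three compounds measured it stands second highest. Compound 2 `COc1ccc(C(F)(F)F)cc1Nc1cc(NC(=O)Nc2c(Cl)cccc2Cl)ncn1` sits nearest, with 89% in this assay, and the step of a number 3.5 percentage points higher from compound 1 to compound 2 (within the scatter) is within the scatter. Compound 3 `COc1cc(NC(=O)Nc2cc(Nc3cc(F)ccc3OC)ncn2)cc(OC)c1` lies furthest away, with 59.5% in this assay, reached by the step of a number 26 percentage points lower from compound 1 to compound 3 (beyond the scatter).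

Compound 4 `Cc1cc(F)cc(Nc2cc(NC(=O)Nc3c(Cl)cccc3Cl)ncn2)c1` has not yet been measured. It differs from compound 1 in one place: 3-fluoro-5-methylphenyl in place of 5-fluoro-2-methoxyphenyl on a nitrogen on an aromatic ring. Among the compounds with values here, the change falls on the same aromatic ring that is altered in the step from compound 1 to compound 2, but it swaps the whole ring rather than a single substituent, so no measured step covers it directly. The step from compound 1 to compound 2 shows that a change of substituent on this ring leaves the number within the scatter, whereas the larger drop seen between compound 1 and compound 3 concerns the other end of the shared core. Compound 4 is therefore expected to stay close to compound 1, with at most a small drop, as a step of a number 7.5 percentage points lower from compound 1 to compound 4 (within the scatter) in this assay. For compound 4 the estimated inhibition is 78%, within a range from 60% to 92%.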

Compound 4, a percentage reported as inhibition, at one concentration (the size of the read-out at that concentration, not a potency): 80%
The estimate for compound 4 lay 2 percentage points below the measured number, and the stated range covers the measured number.
By their numbers in this assay, from the lowest: compound 3; then compounds 4, 1 and 2 (each within the scatter of the next).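

In this assay the exchange of 5-fluoro-2-methoxyphenyl for 3-fluoro-5-methylphenyl on a nitrogen on an aromatic ring comes out as a number 5.5 percentage points lower from compound 1 to compound 4 (within the scatter). The earlier step on this arm changed a single substituent and kept the methoxy group, whereas this one replaces the whole arm with a group that carries no methoxy group, and the number still stays within the scatter. For this pair, then, the methoxy group is not required to keep the inhibition at the one concentration tested, although this single-concentration read-out cannot show whether potency is also retained, and nothing given here offers an explanation for the result.

The compounds shown leave open whether this arm would keep its number with an amine or a carboxylic acid on the ring, or with a longer chain such as propyl in place of the methyl group. They also leave open whether 3-fluoro-5-methylphenyl would behave the same way with the 3,5-dimethoxyphenyl group of compound 3 in place of the 2,6-dichlorophenyl group on the amide-type nitrogen.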